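The compounds below may be only part of what the source reports. "The series", "measured", "known", "first", "only" and "open" are said of these compounds alone.

Measured so far:

Compound 1 `O=C(N/N=C/c1cccc(Br)c1)Nc1cc2c(Nc3ccc(F)c(Cl)c3)ncnc2cc1O[C@H]1CCOC1` — in a functional assay on HepG2 cells (Homo sapiens) for cytotoxicity, read by MTT assay, with a stated time of 72 h (a higher number here means a weaker inhibitor, a lower number a stronger inhibitor), compound 1 gives 32300 nM
Compound 2 `O=C(N/N=C/c1ccc(F)cc1Cl)Nc1cc2c(Nc3ccc(F)c(Cl)c3)ncnc2cc1O[C@H]1CCOC1` — in this assay compound 2 gives 26100 nM
Compound 3 `COc1cc(/C=N/NC(=O)Nc2cc3c(Nc4ccc(F)c(Cl)c4)ncnc3cc2O[C@H]2CCOC2)cc(OC)c1OC` — in this assay compound 3 gives 31200 nM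

The three compounds share one core and differ only in the aryl group on the carbon with a double bond to nitrogen. Compound 3 stands second highest of the three numbers, but every gap is small: a 1.0-fold lower number from compound 1 to compound 3 (0.02 log units; within the scatter), a 1.2-fold higher number from compound 2 to compound 3 (0.08 log units; within the scatter) and a 1.2-fold lower number from compound 1 to compound 2 (0.09 log units; within the scatter) all fall within the scatter, so no ordering among compounds 1, 2 and 3 can be read from these data.

The next compound, compound 4 `O=C(N/N=C/c1ccc(O)cc1)Nc1cc2c(Nc3ccc(F)c(Cl)c3)ncnc2cc1O[C@H]1CCOC1`, continues the same variation: 4-hydroxyphenyl in place of 3,4,5-trimethoxyphenyl on a carbon with a double bond to nitrogen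

All three steps measured at this position, whether to a halogenated ring or to a trimethoxy-substituted ring, left the number in this assay unchanged beyond the scatter. On that basis the exchange for a 4-hydroxyphenyl is not expected to move the number either, and the estimated step is a 1.0-fold lower number from compound 3 to compound 4 (0.02 log units; within the scatter), in no direction beyond the scatter. For compound 4 the expected value in this assay is 30000 nM, with an estimated range from 12000 nM to 75000 nM.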

Compound 4, half-maximal inhibitory concentration: 70 nM
Compound 4: middle estimate off by 430-fold (2.63 log units), on the high side; the whole stated range lies above it.
By their numbers in this assay, from the lowest: compound 4; then compounds 2, 3 and 1 (each within the scatter of the next).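

The aryl group on the carbon with a double bond to nitrogen is not the silent position that compounds 1, 2 and 3 suggested: in this assay there is a 450-fold lower number from compound 3 to compound 4 (2.65 log units; beyond the scatter) and also a 370-fold lower number from compound 2 to compound 4 (2.57 log units; beyond the scatter) and a 460-fold lower number from compound 1 to compound 4 (2.66 log units; beyond the scatter) as well. All three steps are large whether a halogenated ring or the 3,4,5-trimethoxyphenyl ring leaves, so among these four compounds the flat response holds only for the three rings without a hydroxyl, and compound 4 is the one compound that goes against it. The step from compound 3 also changes more than one thing at once, since the 4-hydroxyphenyl group is smaller than the 3,4,5-trimethoxyphenyl group and brings a hydrogen-bond donor where that group has none.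

The compounds shown leave open whether the hydroxyl itself carries the step or whether an unsubstituted phenyl ring would behave the same way. They also leave open whether a methoxy group, an amine or a carboxylic acid in the hydroxyl's place would keep a number in the range of compound 4.

Nothing measured here accounts for the size of this step.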